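ACAT series: aryl substituent change on the cyclopentyl core

This account rests on a few compounds, and the source may have more. Where it says the series, first, only, none or still open, it means among the compounds named here.

Measured so far:
- compound 1 `CC(C)c1cccc(C(C)C)c1NC(=O)NCC1(c2ccc(CC(C)(C)C)cc2)CCCC1` — 159 nM
- compound 2 `CC(C)c1cccc(C(C)C)c1NC(=O)NCC1(c2ccc(OCc3ccccc3)cc2)CCCC1` — 34 nM

In an assay on microsomes for inhibition of acyl-CoA:cholesterol acyltransferase (Oryctolagus cuniculus) (on this read-out higher numbers stand for weaker inhibition and lower numbers for stronger inhibition), compound 2 gives 34 nM and stands as the lowest of the two numbers seen so far; compound 1, with 159 nM in this assay, is the nearest, and the only, comparison. Among the compounds with values here, the single measured step runs a 4.7-fold lower number from compound 1 to compound 2 (0.67 log units; beyond the scatter), a change of the group on the aromatic carbon alone.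

Compound 3 `CC(C)c1cccc(C(C)C)c1NC(=O)NCC1(c2ccc(C(F)(F)F)cc2)CCCC1` is not yet measured in this assay. It differs from compound 2 by trifluoromethyl in place of benzyloxy on an aromatic carbon. Within the data shown here, no measured step uses a trifluoromethyl group at that position, so the step from compound 1 to compound 2 bears on it only in showing that a change of this group alone moved the number by a 4.7-fold lower number from compound 1 to compound 2 (0.67 log units; beyond the scatter), which is beyond the scatter. With the benzyloxy group of compound 2 removed, a number somewhat above that of compound 2 is expected, on the order of the step from compound 1 to compound 2 and in the opposite direction, as a 7.4-fold higher number from compound 2 to compound 3 (0.87 log units; beyond the scatter). Compound 3 is therefore estimated at 250 nM in this assay, within 60 nM to 1000 nM.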

Compound 3, half-maximal inhibitory concentration: 66 nM
Compound 3: the middle estimate sits 3.8-fold (0.58 log units) above what was measured, within the range that was stated.
By their numbers in this assay, from the lowest: compounds 2 and 3 (each within the scatter of the next); then compound 1.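

In this assay, trifluoromethyl takes the place of benzyloxy on this aromatic carbon with a 1.9-fold higher number from compound 2 to compound 3 (0.29 log units; within the scatter), so within these compounds neither the aromatic ring nor the oxygen of benzyloxy is needed to hold the number at this level. Neopentyl is the group that stands apart, with a 2.4-fold lower number from compound 1 to compound 3 (0.38 log units; beyond the scatter) adding a second step beyond the scatter, so compound 1 now has the highest number of the three and the position is seen to tell neopentyl from both other groups. Heavy-atom count does not order this set, as benzyloxy and trifluoromethyl differ in that count yet lie within the scatter of each other, while no evidence bears on what sets neopentyl apart.

Open, as far as these compounds go, is where an amine, a carboxylic acid, a methoxy group or a chlorine atom on the same aromatic carbon would fall relative to compound 2 and compound 3. Also open, from the compounds shown here alone, is whether the same ordering of benzyloxy, trifluoromethyl and neopentyl would hold with a longer chain or a different group in place of the urea-linked part of the shared core.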